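Replacing 4-(trifluoromethyl)phenyl with furan-2-yl in compound 3

The compounds below may be only part of what the source reports. "The series", "measured", "known", "first", "only" and "open" are said of these compounds alone.

In a functional assay on MDA-MB-231 cells (Homo sapiens) for inhibition, read by CCK-8 assay, with a stated time of 48 h (a higher number here means a weaker inhibitor of growth, a lower number a stronger inhibitor of growth), compound 3 `CN1CCN(c2ccc(Nc3ncc(Cl)c(NCc4ccc(C(F)(F)F)cc4)n3)nc2)CC1` gives 19100 nM, the lowest number measured, while compound 1 `Cc1ccccc1Nc1nc(Nc2cccnc2)ncc1Cl` gives 41200 nM. Compound 2 `Cc1ccccc1Nc1nc(NC2CC2)ncc1Cl` reaches only a limit of this assay, > 100000 nM. Compound 4 `CN1CCN(c2ccc(Nc3ncc(Cl)c(NCc4ccco4)n3)nc2)CC1` carries furan-2-yl in place of 4-(trifluoromethyl)phenyl on a saturated chain carbon bound to a nitrogen on an aromatic ring. Among the measured compounds shown here, the only measured step is an at least 2.4-fold higher number from compound 1 to compound 2 (0.38 log units; beyond the scatter). It concerns another group, cyclopropyl in place of pyridin-3-yl, and ends at the limit of > 100000 nM in this assay, at which 1 of the 3 values shown sits, so it bears on this change only indirectly. Taking it as the sole guide to size, a modest upward step is expected, a 2.1-fold higher number from compound 3 to compound 4 (0.32 log units; beyond the scatter). Compound 4 is estimated at 40000 nM, with an expected range of 15000 nM to 90000 nM.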

Compound 4, concentration for 50% growth inhibition: 11000 nM
Beside the measured number, compound 4's estimate is 3.6-fold (0.56 log units) above it, and the stated range ends above it.
By their numbers in this assay, from the lowest: compounds 4 and 3 (each within the scatter of the next); then compound 1. At a limit, above all of these: compound 2.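

In this assay, the change reads as a 1.7-fold lower number from compound 3 to compound 4 (0.24 log units; within the scatter), so this place tolerates the swap: 4-(trifluoromethyl)phenyl and furan-2-yl are not told apart here, although the entering group has 5 heavy atoms, fewer than the group it replaces, and brings a five-membered aromatic ring with 1 hetero atom. The trifluoromethyl group is therefore not required for a number in this range. Nothing shown accounts for this result.

Open, as far as these compounds go, is how a longer chain ending in furan-2-yl, or an amine or carboxylic acid on the benzyl ring, would read at this place.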